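This account rests on a few compounds, and the source may have more. Where it says the series, first, only, none or still open, it means among the compounds named here.

Among the compounds with values here, compound 2 `CCc1cc(-c2nn(C(C)C)c3ncnc(N)c23)no1` gives 531 nM in an assay on isolated protein for inhibition of proto-oncogene tyrosine-protein kinase receptor Ret variant V804M (Homo sapiens), read by radiometric assay and 33P incorporation, in the presence of a further agent that is not named here (on this read-out higher numbers stand for weaker inhibition and lower numbers for stronger inhibition), the highest of the three numbers measured so far. Within the data shown here, compound 1 `Nc1ncnc2c1c(-c1cc(C3CC3)on1)nn2C1CCCCC1` gives 14 nM and compound 3 `Nc1ncnc2c1c(-c1cc(C3CC3)on1)nn2C1CCOCC1` gives 41 nM; both carry a cyclopropyl where compound 2 carries an ethyl, and both also differ from compound 2 on the aromatic nitrogen, so their values show only that compound 2 stands well above them. Among the measured compounds shown here, the single step measured in one place, a 2.9-fold higher number from compound 1 to compound 3 (0.47 log units; beyond the scatter), concerns the group on the aromatic nitrogen and not the alkyl chain. Compound 4 `CC(C)c1cc(-c2nn(C(C)C)c3ncnc(N)c23)no1` differs from compound 2 by methyl in place of hydrogen on a saturated chain carbon bound to an aromatic carbon and a saturated chain carbon. For the measured compounds named here, no measured step bears directly on this change. Because compound 1 gives 14 nM and compound 3 gives 41 nM with a cyclopropyl in place of the ethyl, a modest move toward lower numbers is expected for a branched chain, not a large one. The expected step is a 1.8-fold lower number from compound 2 to compound 4 (0.25 log units; within the scatter). For compound 4 the estimated value is 300 nM, with a range from 80 nM to 1200 nM.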

Compound 4, half-maximal inhibitory concentration: 355 nM
Estimate against measurement, compound 4: 1.2-fold (0.07 log units) below; the measured number falls inside the stated range.
By their numbers in this assay, from the lowest: compound 1; then compound 3; then compounds 4 and 2 (each within the scatter of the next).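

In this assay, going from ethyl to isopropyl gives a 1.5-fold lower number from compound 2 to compound 4 (0.17 log units; within the scatter), so compounds 2 and 4 cannot be told apart. Within the data shown here, this is the first direct reading of this position: with the rest of the molecule unchanged, a methyl in place of hydrogen on the saturated chain carbon bound to the aromatic carbon produces no change beyond the usual scatter. No measurement here explains why this added methyl makes so little difference.

Compounds 1 and 3 differ from compounds 2 and 4 both at this chain and on the aromatic nitrogen, so the shown compounds cannot say how much of that gap comes from either place. Going by these compounds, how a tert-butyl, a longer chain such as n-butyl, or an amine at this position would read also remains open.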